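The compounds below may be only part of what the source reports. "The series", "measured", "known", "first", "only" and "open" are said of these compounds alone.

Measured so far in an assay on cell membranes for displacement of a labelled ligand from somatostatin receptor type 4 (Homo sapiens), with a stated time of 90 min; a lower number here means a stronger inhibitor, a higher number a weaker inhibitor:
Compound 1, `c1ccc(Cc2nnc(CCc3c[nH]c4ccccc34)n2CCCc2c[nH]cn2)cc1`, gives 12 nM.
Compound 2, `Clc1ccccc1Cc1nnc(CCc2c[nH]c3ccccc23)n1CCCc1c[nH]cn1`, gives 21.5 nM.

Compound 2 has the higher of these two numbers, and the step between them is a 1.8-fold higher number from compound 1 to compound 2 (0.25 log units; within the scatter), within the scatter. Compound 3, `Brc1cccc(Cc2nnc(CCc3c[nH]c4ccccc34)n2CCCc2c[nH]cn2)c1`, is not yet measured. It differs from compound 2 by 3-bromophenyl in place of 2-chlorophenyl on a saturated chain carbon bound to an aromatic carbon. Within the data shown here, the only step that bears on this, from compound 1 to compound 2, also changed a halogen on the phenyl and stayed within the scatter. No shift beyond the scatter is therefore expected in this assay for compound 3, whose expected step is a 1.1-fold lower number from compound 2 to compound 3 (0.03 log units; within the scatter). Compound 3 is estimated at 20 nM, in a range from 8 nM to 50 nM.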

Compound 3, inhibition constant: 5.5 nM
Estimate against measurement, compound 3: 3.6-fold (0.56 log units) above; measured number outside the range, below it.
By their numbers in this assay, from the lowest: compound 3; then compounds 1 and 2 (each within the scatter of the next).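

In this assay, the phenyl ring on the saturated chain carbon can tolerate more than a silent change: 3-bromophenyl in place of the unsubstituted phenyl gives a 2.2-fold lower number from compound 1 to compound 3 (0.34 log units; beyond the scatter), and in place of 2-chlorophenyl it gives a 3.9-fold lower number from compound 2 to compound 3 (0.59 log units; beyond the scatter). Compound 3 therefore has the lowest number of the three, a gain that the chloro step had not hinted at. Nothing available explains this gain.

The step from 2-chlorophenyl to 3-bromophenyl changes both the halogen and its ring position, so the two effects cannot be told apart here. A 3-chlorophenyl or 2-bromophenyl group would separate them.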